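Notes on the amine tail: from compound 3 to compound 4

The source may hold more compounds than are shown below. What is called first, only, known or untested is meant among the compounds shown, and "the series" means these compounds.

Measured compounds:
compound 1 `CC(=O)Oc1ccc(C(=O)Nc2cc3ccc(OCC4CCCN(C)C4)c(C)c3oc2=O)cc1CC=C(C)C` gives 1650 nM
compound 2 `CC(=O)Oc1ccc(C(=O)Nc2cc3ccc(OCC4CCN(C)C4)c(C)c3oc2=O)cc1CC=C(C)C` gives 1880 nM
compound 3 `CC(C)=CCc1cc(C(=O)Nc2cc3ccc(OCCCNC(C)(C)C)c(C)c3oc2=O)ccc1O` gives 950 nM

In a functional assay on MCF7 cells (Homo sapiens) for antiproliferative activity (a higher number here means a weaker inhibitor, a lower number a stronger inhibitor), compound 3 has the lowest number of the three, yet its gap to compound 1 and to compound 2 lies within the scatter, so no order among them can be claimed. Going by the values given here, the only measured step, a 1.1-fold higher number from compound 1 to compound 2 (0.06 log units; within the scatter), is within the scatter and concerns a different amine tail than the one altered here.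

Compound 4 `CC(C)=CCc1cc(C(=O)Nc2cc3ccc(OCCCNC(C)(C)c4ccccc4)c(C)c3oc2=O)ccc1O` is not yet measured. It differs from compound 3 as follows: phenyl in place of methyl on a saturated chain carbon bound to an amine nitrogen and two saturated chain carbons. Among the compounds with values here, no measured step touches this part of the molecule, and the one step available says only that a change at the amine tail need not move the number. The expectation for compound 4 in this assay is therefore a value close to that of compound 3, with a 1.1-fold lower number from compound 3 to compound 4 (0.02 log units; within the scatter) meaning no step beyond the scatter, and a wide range because nothing measured bears directly on it. The estimate for compound 4 is 900 nM, between 350 nM and 2500 nM.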

Compound 4, half-maximal inhibitory concentration: 1070 nM
The estimate for compound 4 lay 1.2-fold (0.08 log units) below the measured number, and the stated range covers the measured number.
By their numbers in this assay, from the lowest: compounds 3, 4, 1 and 2 (each within the scatter of the next).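

In this assay, phenyl in place of methyl on a saturated chain carbon bound to an amine nitrogen and two saturated chain carbons gives a 1.1-fold higher number from compound 3 to compound 4 (0.05 log units; within the scatter) and so stays within the scatter. Going by these compounds alone, this is the first reading at this position, and it shows that the change from tert-butyl to 1-methyl-1-phenylethyl, which adds one six-membered aromatic ring of carbon only, leaves no readable step on the number. No measurement at hand bears on why the number holds here.

Going by these compounds, it remains open whether a carboxylic acid or a pyridine ring on this same carbon, or a longer chain leading to the amine nitrogen, would give a step beyond the scatter. Compounds 1 and 2 differ from compound 3 and compound 4 in more than one place, so the two pairs cannot be set against each other.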